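Three bromoacrylamides on a shared core

The source may report more compounds than this note shows. Statements on the series, on what has been measured and on what is new or still open speak of the compounds shown alone.

Compound 1, `C=C(Br)C(=O)Nc1cccc(-c2cn3nc(-c4ccc(CC)cc4)sc3n2)c1`, gives 3300 nM in a functional assay on FM3A cells (Mus musculus) for inhibition, read by cell counting, with a stated time of 2 days; a lower number here means a stronger inhibitor, a higher number a weaker inhibitor.
Compound 2, `C=C(Br)C(=O)Nc1cccc(-c2cn3nc(Cc4ccc(Cl)cc4)sc3n2)c1`, gives 1100 nM in this assay.
Compound 3, `C=C(Br)C(=O)Nc1cccc(-c2cn3nc(-c4cccc(OC)c4)sc3n2)c1`, gives 500 nM in this assay.

Compound 3 stands lowest of the three numbers: the nearest is compound 2, a 2.2-fold lower number from compound 2 to compound 3 (0.34 log units; beyond the scatter), and the furthest is compound 1, a 6.6-fold lower number from compound 1 to compound 3 (0.82 log units; beyond the scatter). Compound 4, `C=C(Br)C(=O)Nc1cccc(-c2cn3nc(Cc4ccc(OC)cc4)sc3n2)c1`, differs from compound 3 by 4-methoxybenzyl in place of 3-methoxyphenyl on an aromatic carbon. The step that bears most on this is a 3.0-fold lower number from compound 1 to compound 2 (0.48 log units; beyond the scatter), where a benzyl likewise took the place of a phenyl, though with a different substituent; taken with a 2.2-fold lower number from compound 2 to compound 3 (0.34 log units; beyond the scatter) it shows the benzyl compound giving a higher number than the directly attached aryl. A modest rise in this assay is therefore expected, a 1.8-fold higher number from compound 3 to compound 4 (0.26 log units; within the scatter). Compound 4 is estimated at 900 nM, within 350 nM to 2500 nM.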

Compound 4, half-maximal inhibitory concentration: 850 nM
Compound 4: the middle estimate sits 1.1-fold (0.02 log units) above what was measured, within the range that was stated.
By their numbers in this assay, from the lowest: compounds 3, 4 and 2 (each within the scatter of the next, the first and the last beyond it); then compound 1.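

In this assay the 4-methoxybenzyl and the 3-methoxyphenyl cannot be told apart at this position (a 1.7-fold higher number from compound 3 to compound 4 (0.23 log units; within the scatter)), and methoxy in place of chloro on the benzyl stays within the scatter too (a 1.3-fold lower number from compound 2 to compound 4 (0.11 log units; within the scatter)). Only the 4-ethylphenyl of compound 1 now stands apart from all the others (a 3.9-fold lower number from compound 1 to compound 4 (0.59 log units; beyond the scatter)), so a benzyl does not by itself set the number. Nothing available explains these steps.

Still open, as far as these compounds go, is how an amine or a carboxylic acid on the benzyl ring would read, and whether a longer chain between the core and that ring would move the number.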